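Shifting the ring nitrogen in a quinoline-ether amide series

The source may report more compounds than this note shows. Statements on the series, on what has been measured and on what is new or still open speak of the compounds shown alone.

Compounds measured so far:
compound 1, `COc1ccc2nc(C)cc(OCC(=O)NCc3cc(C)cc(C)c3)c2c1`, 5.25
compound 2, `COc1ccc2nc(C)cc(OCC(=O)Nc3ccccc3)c2c1`, 4.28
compound 3, `COc1ccc2nc(C)cc(OCC(=O)Nc3ccccn3)c2c1`, 3.49

In a physicochemical assay for lipophilicity, read by HPLC, in phosphate buffer, measured as chromatographic lipophilicity, at pH 7.4 (a lower number here means a more polar compound, a higher number a more lipophilic compound), compound 3 stands lowest of the three, with compound 2 nearest, as a number 0.79 log units lower from compound 2 to compound 3 (beyond the scatter) shows, and compound 1 furthest, as a number 1.76 log units lower from compound 1 to compound 3 (beyond the scatter) shows. Compound 4, `COc1ccc2nc(C)cc(OCC(=O)Nc3ccncc3)c2c1`, differs from compound 3 only in the amide substituent: pyridin-4-yl in place of pyridin-2-yl on an amide-type nitrogen. Within the data shown here, no measured step moves a ring nitrogen within the same ring; the steps into compound 3 both bring pyridin-2-yl in from a different group, so they frame the range rather than the direction. A step of modest size at most, likely downward, is expected, estimated as a number 0.39 log units lower from compound 3 to compound 4 (beyond the scatter). Compound 4 is therefore expected to give about 3.1, between 2.6 and 3.6, in this assay .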

Compound 4, distribution coefficient: 2.5
The estimate for compound 4 lay 0.60 log units above the measured number; the measured number lies below the stated range.
By their numbers in this assay, from the lowest: compound 4; then compound 3; then compound 2; then compound 1.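

In this assay, moving the ring nitrogen with no change in atoms still gives a clear step, a number 0.99 log units lower from compound 3 to compound 4 (beyond the scatter), so pyridin-4-yl and pyridin-2-yl are not interchangeable on this amide-type nitrogen. Pyridin-4-yl also widens the series' span, with a number 1.78 log units lower from compound 2 to compound 4 (beyond the scatter) and a number 2.75 log units lower from compound 1 to compound 4 (beyond the scatter). Nothing at hand explains why the nitrogen's place matters. Still open, going by these compounds, is whether this order between the two pyridinyl groups holds on a longer chain, and how an amine or a carboxylic acid added to pyridin-4-yl would read in this assay.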